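A few compounds are considered here, and "the series" means these few. Any claim that something is new, unique, unknown or untested is made for them only; others in the source may bear on it.

Compound 1 `COc1ccccc1NC(=O)N[C@H](C)c1ccccc1` was tested in an ADME assay on the whole organism with Oryza sativa as the target, tested at 1 uM; a lower number here means a stronger effect, a higher number a weaker effect of the compound at the concentration tested; in this assay compound 1 gives 105%. Compound 3 `CC(=O)c1ccccc1NC(=O)N[C@H](C)c1ccccc1` differs from compound 1 by a single change, (acetyl in place of methoxy on an aromatic carbon), and in this assay compound 3 gives 95%. The step between the two, a number 10 percentage points lower from compound 1 to compound 3 (within the scatter), is therefore small. Compound 2 `COc1cccc(NC(=O)N[C@H](C)c2ccccc2)c1` is built from the same atoms as compound 1, joined differently; the difference between the two cores is not broken down here. In this assay compound 2 gives 92%, which stands beyond the scatter from compound 1 but within the scatter of compound 3.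

Compound 4 `CC(=O)c1cccc(NC(=O)N[C@H](C)c2ccccc2)c1` has not yet been measured in this assay. It differs from compound 2 by acetyl in place of methoxy on an aromatic carbon. This is the same kind of change as that from compound 1 to compound 3, though not the same: in the earlier pair the change sits ortho to a large group, whereas in compound 4 it sits meta to a large group. Since the change occurs only twice among the compounds shown, the earlier pair is the only guide.

Because a number 10 percentage points lower from compound 1 to compound 3 (within the scatter) stayed within the scatter, the step from compound 2 to compound 4 is expected to be similarly small, a number 5 percentage points lower from compound 2 to compound 4 (within the scatter). Compound 4 is accordingly estimated to give 87% in this assay, with the expected range running from 72% to 102%.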

Compound 4, a percentage reported as activity, at one concentration (the size of the read-out at that concentration, not a potency): 88%
Compound 4: the middle estimate sits 1 percentage points below what was measured; the range from low to high includes it.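

In this assay, acetyl in place of methoxy on an aromatic carbon, here meta to a large group, gives a number 4 percentage points lower from compound 2 to compound 4 (within the scatter). Set beside the earlier pair, the new step shows that the change behaves alike on the two cores as far as this read-out can tell: the same change on two cores in this assay, a number 10 percentage points lower (within the scatter) from compound 1 to compound 3 and a number 4 percentage points lower (within the scatter) from compound 2 to compound 4, 6 percentage points apart, within the scatter of two such steps Neither step rises above the scatter, so the two pairs show only that this swap did not move the read-out measurably on either core; they do not show that the change has a real effect of its own, of a size that could be carried over, or that the same would hold on any further core in the series.

The compounds shown leave open how an amine, a carboxylic acid or a longer chain would read in this assay on the same aromatic carbon, since methoxy and acetyl are the only groups compared there. They also leave open whether a change elsewhere in the molecule would shift the read-out by more than the scatter on either core.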